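A Benzyl Thioether Where an Allyl Once Stood

The compounds below may be only part of what the source reports. "The series", "measured", "known", "first", "only" and "open" are said of these compounds alone.

Of the compounds shown here, three sharing one core have been measured in a functional assay on MGC-803 cells (Homo sapiens) for inhibition, read by MTT assay, with a stated time of 72 h; on this read-out higher numbers stand for weaker inhibition and lower numbers for stronger inhibition. Compound 1 `Cc1cc(N2CC[C@@H](C)[C@@H](N(C)c3ncnc4[nH]ccc34)C2)n2ncnc2n1` gives 4350 nM, compound 2 `CCCSc1nc2nc(C)cc(N3CC[C@@H](C)[C@@H](N(C)c4ncnc5[nH]ccc45)C3)n2n1` gives 15500 nM, and compound 3 `C=CCSc1nc2nc(C)cc(N3CC[C@@H](C)[C@@H](N(C)c4ncnc5[nH]ccc45)C3)n2n1` gives 32600 nM, the highest of the three numbers. Both sulfanyl substituents raised the number: a 3.6-fold higher number from compound 1 to compound 2 (0.55 log units; beyond the scatter) and a 7.5-fold higher number from compound 1 to compound 3 (0.87 log units; beyond the scatter), while within the pair a 2.1-fold higher number from compound 2 to compound 3 (0.32 log units; beyond the scatter). Compound 4 `Cc1ccc(CSc2nc3nc(C)cc(N4CC[C@@H](C)[C@@H](N(C)c5ncnc6[nH]ccc56)C4)n3n2)cc1` differs from compound 3 by 4-methylphenyl in place of vinyl on a saturated chain carbon bound to a sulfur. Within the data shown here, no measured step places an aromatic ring at this position, so the precedent is indirect; the closest steps point modestly upward. Compound 4 is therefore expected to stay near compound 3, a 1.1-fold higher number from compound 3 to compound 4 (0.03 log units; within the scatter), with a wide band. The estimate for compound 4 in this assay is 35000 nM, between 10000 nM and 120000 nM.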

Compound 4, half-maximal inhibitory concentration: 5860 nM
Beside the measured number, compound 4's estimate is 6.0-fold (0.78 log units) above it; the whole stated range lies above it.
By their numbers in this assay, from the lowest: compounds 1 and 4 (each within the scatter of the next); then compound 2; then compound 3.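

Replacing the allyl group with 4-methylbenzyl reverses the rise seen with the earlier sulfanyl substituents, giving a 5.6-fold lower number from compound 3 to compound 4 (0.75 log units; beyond the scatter) and a 2.6-fold lower number from compound 2 to compound 4 (0.42 log units; beyond the scatter) on this saturated chain carbon bound to a sulfur. The sulfanyl substituent therefore does not always raise the number, and compound 4 goes against the pattern set by compound 2 and compound 3. Against the unsubstituted parent the result is a 1.3-fold higher number from compound 1 to compound 4 (0.13 log units; within the scatter) and so shows no change. As far as these compounds go, whether the benzyl ring alone suffices, or the methyl on it matters, remains open, as does the effect of an amine or carboxylic acid on that ring. No available evidence explains the reversal.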